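Piperidinyl replaces cyclohexylmethylamino on the shared furyl core

A few compounds are considered here, and "the series" means these few. Any claim that something is new, unique, unknown or untested is made for them only; others in the source may bear on it.

Measured so far:
compound 1 `CCOC(=O)c1cnc(NC2CC2)n2nc(-c3ccco3)nc12`: 60.7 nM
compound 2 `CCOC(=O)c1cnc(NCC2CCCCC2)n2nc(-c3ccco3)nc12`: 432 nM

In an assay on CHO cells for displacement of a labelled ligand from adenosine receptor A1 (Homo sapiens) (a higher number here means a weaker inhibitor, a lower number a stronger inhibitor), compound 1 gives 60.7 nM and compound 2 gives 432 nM. Within this pair, compound 2 holds the higher of the two numbers in this assay, and the only step measured so far is a 7.1-fold higher number from compound 1 to compound 2 (0.85 log units; beyond the scatter), a change in which the substituent on the ring nitrogen grows from cyclopropyl to cyclohexylmethyl.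

Compound 3 `CCOC(=O)c1cnc(N2CCCCC2)n2nc(-c3ccco3)nc12` is not yet measured. It differs from compound 2 in one place: piperidin-1-yl in place of (cyclohexylmethyl)amino on an aromatic carbon. The change removes the hydrogen-bond donor that both measured compounds carry, and it also shortens the group by the counted atoms. Going by the values given here, no measured step covers the loss of this donor, so the step from compound 1 to compound 2 bears on it only indirectly, by showing that the ring-nitrogen substituent matters for the number in this assay.

Given the lack of a direct precedent and the removal of the donor present in compound 2, the number for compound 3 in this assay is expected to rise, by an estimated 2.1-fold higher number from compound 2 to compound 3 (0.32 log units; beyond the scatter). Compound 3 is therefore estimated at 900 nM, in a range from 200 nM to 4000 nM.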

Compound 3, inhibition constant: 8860 nM
Estimate against measurement, compound 3: 9.8-fold (0.99 log units) below; the whole stated range lies below it.
By their numbers in this assay, from the lowest: compound 1; then compound 2; then compound 3.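

In this assay, the change at this position, para to the ethoxycarbonyl group, gives a 21-fold higher number from compound 2 to compound 3 (1.31 log units; beyond the scatter) when piperidin-1-yl takes the place of (cyclohexylmethyl)amino and a 150-fold higher number from compound 1 to compound 3 (2.16 log units; beyond the scatter) when it takes the place of cyclopropylamino. Both steps exceed a 7.1-fold higher number from compound 1 to compound 2 (0.85 log units; beyond the scatter) in size, so among these three compounds, exchanging one substituent on the amino nitrogen for another moves the number less than replacing the amino group with piperidin-1-yl, the only group of the three without a hydrogen-bond donor. No measured information accounts for the size of these steps.

The donor is lost in the same change that places the ring nitrogen directly on the aromatic carbon, so the compounds shown do not separate these two differences; a tertiary amine such as dimethylamino or methyl(cyclohexylmethyl)amino would bear on that question. On these data alone, whether the high number belongs to piperidin-1-yl alone or extends to other cyclic amines, such as pyrrolidin-1-yl or morpholin-4-yl, also remains open.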